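Reversed amide at the fused-ring carbon: compound 2 to compound 4

The source may report more compounds than this note shows. Statements on the series, on what has been measured and on what is new or still open speak of the compounds shown alone.

Measured in a functional assay on CAL1 cells for inhibition of chemerin-like receptor 1 (Homo sapiens), with a stated time of 45 min; a higher number here means a weaker inhibitor, a lower number a stronger inhibitor:
compound 1 `C[C@H](c1ccc(-c2cc(Cl)ccc2-c2nc(=O)o[nH]2)cc1)N(CC1CC1)c1nc2c(C(=O)O)cccc2o1` gives 1.3 nM
compound 2 `CCCCN(c1nc2c(C(=O)NC)cccc2o1)[C@H](C)c1ccc(-c2ccccc2-c2nnn[nH]2)cc1` gives 110 nM
compound 3 `Cc1ccc(-c2nc(=O)o[nH]2)c(-c2ccc([C@@H](C)N(CC3CC3)c3nc4c(C(=O)O)cccc4o3)cc2)c1` gives 3.2 nM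

Compound 2 stands highest of the three numbers in this assay; compound 3 sits nearest to it, compound 1 furthest, both gaps beyond the scatter. For the measured compounds named here, the only single-point step so far, a 2.5-fold higher number from compound 1 to compound 3 (0.39 log units; beyond the scatter), concerns the chloro-bearing ring and does not touch the fused core. Compound 4 `CCCCN(c1nc2c(NC(C)=O)cccc2o1)[C@H](C)c1ccc(-c2ccccc2-c2nnn[nH]2)cc1` differs from compound 2 by acetamido in place of methylcarbamoyl on an aromatic carbon. Going by the values given here, no measured step bears on this change, so no direction can be drawn from the series; the expectation is a step from compound 2 to compound 4 of a 1.4-fold higher number from compound 2 to compound 4 (0.13 log units; within the scatter), not clearly beyond the scatter. Compound 4 is therefore estimated at 150 nM, with a range from 40 nM to 600 nM.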

Compound 4, half-maximal inhibitory concentration: 22 nM
For compound 4 the middle estimate is 6.8-fold (0.83 log units) above the measured one; the whole stated range lies above it.
By their numbers in this assay, from the lowest: compound 1; then compound 3; then compound 4; then compound 2.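

In this assay, reversing the amide at this carbon gives a 5.0-fold lower number from compound 2 to compound 4 (0.70 log units; beyond the scatter) with the same atoms joined differently and the same counts of donors and acceptors. Acetamido and methylcarbamoyl are therefore not interchangeable at this place, and the direction of the amide matters, not just its presence. Nothing measured here explains the difference.

Still open, on these data alone, is whether a free amine or a longer acyl chain, such as propionamido, at this carbon would extend the step. As far as these compounds go, it is also open whether the step holds with the tetrazole replaced.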